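Changing the chain end on a shared core

This account rests on a few compounds, and the source may have more. Where it says the series, first, only, none or still open, it means among the compounds named here.

Compound 1 `CSc1nc(NCc2ccc(-c3ccccn3)cc2)c2[nH]nc(C(C)C)c2n1` (783 nM)
Compound 2 `CC(C)c1n[nH]c2c(NCc3ccc(-c4ccccn4)cc3)nc(SCCNC(=N)N)nc12` (390 nM)

In a functional assay on HT cells (Homo sapiens) for antiproliferative activity, read by fluorescence, with a stated time of 72 h (a higher number here means a weaker inhibitor of growth, a lower number a stronger inhibitor of growth), only these two numbers exist so far, and compound 2 (390 nM) lies within the scatter of compound 1. Compound 3 `CC(C)c1n[nH]c2c(NCc3ccc(-c4ccccn4)cc3)nc(SCCC(N)=O)nc12` keeps the core of compound 2 and changes only the end of its chain (a group of 3 heavy atoms (1 carbon, 1 nitrogen, 1 oxygen; no ring) in place of a group of 4 heavy atoms (1 carbon, 3 nitrogen; no ring), on a saturated chain carbon, two bonds along the chain from a sulfur) so that a carbamoyl enters on a saturated chain carbon, two bonds along the chain from a sulfur. Going by the values given here, the one measured step that bears on this, a chain end put in place of a hydrogen, was small (a 2.0-fold lower number from compound 1 to compound 2 (0.30 log units; within the scatter)) and gives no ground for expecting a large move here. In this assay no change beyond the scatter is therefore expected, and the estimated step (a 1.4-fold higher number from compound 2 to compound 3 (0.15 log units; within the scatter)) has no firm direction. The estimate for compound 3 is 550 nM as the expected value (range 220 nM to 1300 nM).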

Compound 3, concentration for 50% growth inhibition: 120 nM
Compound 3: the middle estimate sits 4.6-fold (0.66 log units) above what was measured; the measured number lies below the stated range.
By their numbers in this assay, from the lowest: compound 3; then compounds 2 and 1 (each within the scatter of the next).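

In this assay, what ends the chain matters: with carbamoyl as the chain end, on a saturated chain carbon, two bonds along the chain from a sulfur, the number falls beyond the scatter (a 3.3-fold lower number from compound 2 to compound 3 (0.51 log units; beyond the scatter)). Set against the hydrogen of compound 1, carbamoylmethyl on a saturated chain carbon bound to a sulfur also gives a step beyond the scatter (a 6.5-fold lower number from compound 1 to compound 3 (0.81 log units; beyond the scatter)), whereas the chain end of compound 2 stayed within it (a 2.0-fold lower number from compound 1 to compound 2 (0.30 log units; within the scatter)), so adding a chain here does not by itself decide the size of the step. Nothing available explains why the carbamoyl end gives the lower number.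

As far as these compounds go, it remains open whether a carboxylic acid or an amine at this chain end would do as well as carbamoyl. Also open, from the compounds shown here alone, is how a longer chain carrying the carbamoyl, or a methyl group in place of an amide hydrogen, would change the number.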